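Moving the nitro group around the pendant phenyl ring

The compounds below may be only part of what the source reports. "The series", "measured", "known", "first", "only" and "open" are said of these compounds alone.

Compound 1 `CN(C)c1ccc(/C=C2\CCC/C(=C\c3ccccc3[N+](=O)[O-])C2=O)cc1` carries a 2-nitrophenyl on the chain carbon attached to the shared core; in a functional assay on CCRF-CEM cells (Homo sapiens) for cytotoxicity, with a stated time of 72 h (on this read-out lower numbers stand for stronger inhibition and higher numbers for weaker inhibition), compound 1 gives 168000 nM. Compound 2 `CN(C)c1ccc(/C=C2\CCC/C(=C\c3ccc([N+](=O)[O-])cc3)C2=O)cc1` carries a 4-nitrophenyl in the same place. In this assay compound 2 reaches only a limit, > 500000 nM, so for compound 2 no number is known, only a bound (the limit of > 500000 nM in this assay, at which 1 of the 2 values shown sits). The step of an at least 2.9-fold higher number from compound 1 to compound 2 (0.47 log units; beyond the scatter) shows that relocating the nitro group from the 2- to the 4-position costs activity.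

Compound 3 `CN(C)c1ccc(/C=C2\CCC/C(=C\c3cccc([N+](=O)[O-])c3)C2=O)cc1` is the third isomer: 3-nitrophenyl in place of 4-nitrophenyl on a double-bonded chain carbon bound to a double-bonded ring carbon. For the measured compounds named here, no measured step touches a 3-nitrophenyl, so the only step that bears on this change is an at least 2.9-fold higher number from compound 1 to compound 2 (0.47 log units; beyond the scatter), which fixes compound 2 at the ceiling and compound 1 as the stronger member of the pair. Compound 3 is expected to lie between these two, with a real chance of falling at the limit as compound 2 does; the estimate for compound 3 in this assay is 350000 nM, with a range from 120000 nM to 1000000 nM. The expected step is therefore an at least 1.4-fold lower number from compound 2 to compound 3 (0.15 log units; that floor lies within the scatter), an estimated modest gain that remains uncertain.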

Compound 3, half-maximal inhibitory concentration: 11700 nM
For compound 3 the middle estimate is 30-fold (1.48 log units) above the measured one, outside the stated range (below it).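

In this assay the place on a double-bonded chain carbon bound to a double-bonded ring carbon proves highly sensitive to the location of the nitro group, and the 3-nitrophenyl gives the most active of the three isomers. This shows up as a 14-fold lower number from compound 1 to compound 3 (1.16 log units; beyond the scatter) and as an at least 42-fold lower number from compound 2 to compound 3 (1.63 log units; beyond the scatter), so the earlier order of 2-nitrophenyl ahead of 4-nitrophenyl was incomplete, and activity does not change steadily along the sequence of 2-, 3- and 4-nitrophenyl, as compound 3 stands ahead of both other isomers. Going by these compounds, the step from compound 2 rests on a limit rather than a number, so its true size remains unknown: the limit of > 500000 nM in this assay, at which 1 of the 3 values shown sits.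

The compounds shown leave open whether the gain of compound 3 is tied to the nitro group itself or would also appear with another group, such as a 3-aminophenyl or a 3-carboxyphenyl, in the same place. They also leave open whether this order of the three isomers would hold in any other cell line.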